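The source may hold more compounds than are shown below. What is called first, only, known or untested is meant among the compounds shown, and "the series" means these compounds.

For the measured compounds named here, compound 1 `CN(C)CCn1c(=O)c(=Cc2ccc(F)cc2F)s/c1=C1\C(=O)Nc2cc(F)ccc21` stands at 6460 nM in a functional assay on HT-29 cells (Homo sapiens) for inhibition, read by MTT assay, with a stated time of 72 h (a higher number here means a weaker inhibitor, a lower number a stronger inhibitor), the higher of the two numbers measured so far; compound 2 `CCN(CC)CCCn1c(=O)c(=Cc2ccc(F)cc2F)s/c1=C1\C(=O)Nc2cc(F)ccc21` gives 1520 nM, and a 4.3-fold lower number from compound 1 to compound 2 (0.63 log units; beyond the scatter) is the only measured step. Compound 3 `COc1ccc(OC)c(C=c2s/c(=C3\C(=O)Nc4cc(F)ccc43)n(CCN(C)C)c2=O)c1` differs from compound 1 by 2,5-dimethoxyphenyl in place of 2,4-difluorophenyl on a double-bonded chain carbon bound to an aromatic carbon. Going by the values given here, the one measured step concerns the amine on the saturated chain and not the aryl group on the double-bonded chain carbon, so it does not bear on this change; no measured pair shows what exchanging the aryl group does here. With nothing to anchor a direction, no step beyond the scatter is expected in this assay for this change, and the range must be kept wide. Compound 3 is expected to give 6500 nM, between 1600 nM and 26000 nM. The step expected is a 1.0-fold higher number from compound 1 to compound 3 (0.00 log units; within the scatter), within the scatter.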

Compound 3, half-maximal inhibitory concentration: 4450 nM
Compound 3: the middle estimate sits 1.5-fold (0.16 log units) above what was measured, and the stated range covers the measured number.
By their numbers in this assay, from the lowest: compound 2; then compounds 3 and 1 (each within the scatter of the next).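

In this assay, the aryl group on the double-bonded chain carbon bound to an aromatic carbon now has a measured exchange: 2,5-dimethoxyphenyl in place of 2,4-difluorophenyl gives a 1.5-fold lower number from compound 1 to compound 3 (0.16 log units; within the scatter). For the compounds shown here, with the dimethylamino chain of compound 1 held fixed, going from a group with 0 hydrogen-bond acceptors to one with 2 does not move the number beyond the scatter, so the only step beyond the scatter so far remains the one on the amine chain, a 4.3-fold lower number from compound 1 to compound 2 (0.63 log units; beyond the scatter). No measurement at hand offers an explanation for this result.

The compounds shown leave open whether this aryl exchange reads the same on the diethylamino chain of compound 2. They also leave open what an unsubstituted phenyl or a pyridyl group would give at this place.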